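This account rests on a few compounds, and the source may have more. Where it says the series, first, only, none or still open, it means among the compounds named here.

In a physicochemical assay for solubility, read by nephelometry (a higher number here means a more soluble compound, a lower number a less soluble compound), three compounds that share one core have been tested so far. Compound 1 `CC1(C)C(=O)N(c2ccc(SC(F)(F)F)cc2)C(=O)N1Cc1ccnc(F)c1` gives 0.032 ug/mL. Compound 2 `COc1ccc(CNc2cc(CN3C(=O)N(c4ccc(SC(F)(F)F)cc4)C(=O)C3(C)C)ccn2)cc1` gives only a limit of the assay, < 0.027 ug/mL. Compound 3 `CNC(=O)c1cc(CN2C(=O)N(c3ccc(SC(F)(F)F)cc3)C(=O)C2(C)C)ccn1` also gives only a limit, < 0.023 ug/mL, so its standing is not a true number.

Compound 4 `CCc1cc(CN2C(=O)N(c3ccc(SC(F)(F)F)cc3)C(=O)C2(C)C)ccn1` has ethyl in place of methylcarbamoyl on an aromatic carbon. Earlier changes at this same place offer the best guide. Replacing fluoro gave an at least 1.1-fold lower number from compound 1 to compound 2 (0.07 log units; that floor lies within the scatter), and another replacement gave an at least 1.3-fold lower number from compound 1 to compound 3 (0.14 log units; that floor lies within the scatter). The remaining comparison is a step that the two limits leave unreadable from compound 2 to compound 3.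

None of these steps can be read as a change beyond the scatter, so no step beyond the scatter is expected in this assay, in either direction. Within the data shown here, the only true number, compound 1 at 0.032 ug/mL, anchors the expectation. The estimated step is an at least 1.3-fold higher number from compound 3 to compound 4 (0.11 log units; that floor lies within the scatter). Compound 4 is estimated at 0.03 ug/mL, with an expected range of 0.01 ug/mL to 0.09 ug/mL.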

Compound 4, solubility: < 0.022 ug/mL
Compound 4 gave a limit, no number; the forecaster's own chance of this, stated with the estimate: 45%; middle value at least 1.3-fold (0.13 log units) from the limit.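

At this position, next to the ring nitrogen, a group without hydrogen-bond donors or acceptors, ethyl, ends at a limit in this assay, just as the methylcarbamoyl group that it replaces did. Set against fluoro, ethyl gives an at least 1.4-fold lower number from compound 1 to compound 4 (0.16 log units; that floor lies within the scatter), so this change gives no readable evidence of a real difference, and compound 1 remains the only compound here with a true number. The steps among compound 2, compound 3 and compound 4 cannot be read, because each of them rests on limits alone, the newest being: the limit of < 0.022 ug/mL in this assay, at which 1 of the 4 values shown sits.

Going by these compounds, it remains open whether another group at this place, such as an amine or a carboxylic acid, would give a true number in this assay. On these data alone, the true order of compound 2, compound 3 and compound 4 also remains open.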